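The compounds below may be only part of what the source reports. "The series", "measured", "known", "first", "only" and "open" are said of these compounds alone.

Compound 3 `Cc1nn(C(=O)c2cccnc2)c(N)c1-c1ccc(Cl)c(Cl)c1` carries a pyridin-3-yl group on the carbonyl carbon attached to the ring nitrogen of the shared core. In an assay on Sf9 cells for inhibition of mitogen-activated protein kinase kinase kinase 14 (Homo sapiens), read by ADP-Glo, with a stated time of 60 min (a higher number here means a weaker inhibitor, a lower number a stronger inhibitor), compound 3 gives > 100000 nM, which is a limit of the assay rather than a number. Compound 1 `CCC(=O)n1nc(C)c(-c2ccc(Cl)c(Cl)c2)c1N` gives 27400 nM. Compound 2 `CCCC(=O)n1nc(C)c(-c2ccc(Cl)c(Cl)c2)c1N` gives > 100000 nM, also a limit. The step of an at least 3.6-fold higher number from compound 1 to compound 3 (0.56 log units; beyond the scatter) lies beyond the scatter. The step that the two limits leave unreadable from compound 2 to compound 3 cannot be sized, as the limit of > 100000 nM in this assay, at which 2 of the 3 values shown sit, shows. Compound 4 `Cc1nn(C(=O)OC(C)(C)C)c(N)c1-c1ccc(Cl)c(Cl)c1` differs from compound 3 by tert-butoxy in place of pyridin-3-yl on a carbonyl carbon. Going by the values given here, no measured step exchanges a ring for tert-butoxy on this carbon, and with two of three values at the limit of > 100000 nM in this assay, at which 2 of the 3 values shown sit, compound 4 is expected to stay weak. The estimated value for compound 4 is 80000 nM, with a range from 20000 nM to 300000 nM. The expected step is an at least 1.2-fold lower number from compound 3 to compound 4 (0.09 log units; that floor lies within the scatter), within the scatter.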

Compound 4, half-maximal inhibitory concentration: > 100000 nM
Compound 4 gave a limit, no number (the forecaster's own chance of this, stated with the estimate: 60%); middle value at least 1.2-fold (0.09 log units) away from the limit.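

With tert-butoxy on the carbonyl carbon, a group with no ring, compound 4 in this assay also reaches only a limit, not a number. Ethyl therefore remains the only group shown on this carbon that gives a measured value, and the change to tert-butoxy gives an at least 3.6-fold higher number from compound 1 to compound 4 (0.56 log units; beyond the scatter). The steps from compound 2 and from compound 3 to compound 4 cannot be read, as all three compounds sit at the same limit: the limit of > 100000 nM in this assay, at which 3 of the 4 values shown sit.

Going by these compounds, it remains open whether methyl or an amine on this carbonyl carbon would give a measurable value. On these data alone, the order of compound 2, compound 3 and compound 4 also remains unknown.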